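From Dimethoxyphenyl to Cyanophenyl on the Amide

A few compounds are considered here, and "the series" means these few. Any claim that something is new, unique, unknown or untested is made for them only; others in the source may bear on it.

Three compounds sharing one core differ only in the aryl group on the carbonyl carbon of the amide. Compound 1 `O=C(Nc1cccc(-c2oc3cc(-c4ccc(F)cc4)ccc3c(=O)c2O)c1)c1ccc(Cl)cc1` carries a 4-chlorophenyl there; in a functional assay on HeLa cells (Homo sapiens) for antiproliferative activity, read by CCK-8 assay, with a stated time of 72 h (a higher number here means a weaker inhibitor, a lower number a stronger inhibitor), compound 1 gives 3670 nM. Compound 2 `O=C(Nc1cccc(-c2oc3cc(-c4ccc(F)cc4)ccc3c(=O)c2O)c1)c1cccc(F)c1`, with a 3-fluorophenyl, gives 8780 nM in this assay, a step of a 2.4-fold higher number from compound 1 to compound 2 (0.38 log units; beyond the scatter). Compound 3 `COc1cc(OC)cc(C(=O)Nc2cccc(-c3oc4cc(-c5ccc(F)cc5)ccc4c(=O)c3O)c2)c1` carries a 3,5-dimethoxyphenyl and gives 2700 nM in this assay. This is the lowest number of the three, yet the gap a 1.4-fold lower number from compound 1 to compound 3 (0.13 log units; within the scatter) lies within the scatter, so the two cannot be ordered, while the gap a 3.3-fold lower number from compound 2 to compound 3 (0.51 log units; beyond the scatter) lies beyond the scatter.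

Compound 4 `N#Cc1ccc(C(=O)Nc2cccc(-c3oc4cc(-c5ccc(F)cc5)ccc4c(=O)c3O)c2)cc1` takes one step from compound 3: 4-cyanophenyl in place of 3,5-dimethoxyphenyl on a carbonyl carbon. Among the compounds with values here, no measured step shows this exact exchange. The three exchanges of the aryl group are the ones that bear on it, and the widest of them is a 2.4-fold higher number from compound 1 to compound 2 (0.38 log units; beyond the scatter). The 4-cyanophenyl, like the 4-chlorophenyl of compound 1, is a singly substituted phenyl, and compound 1 anchors the expectation because compound 1 gives 3670 nM. The step of a 1.5-fold higher number from compound 3 to compound 4 (0.17 log units; within the scatter) is therefore expected to be small, a slight rise in the number. Compound 4 is expected to give 4000 nM in this assay, within a range of 1500 nM to 10000 nM.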

Compound 4, half-maximal inhibitory concentration: 23300 nM
Beside the measured number, compound 4's estimate is 5.8-fold (0.77 log units) below it; the whole stated range lies below it.
By their numbers in this assay, from the lowest: compounds 3 and 1 (each within the scatter of the next); then compound 2; then compound 4.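

The aryl group on this carbonyl carbon, whose other neighbour is the amide-type nitrogen, proves more sensitive than the first three compounds suggested: in this assay, cyano in place of chloro on an aromatic carbon gives a 6.3-fold higher number from compound 1 to compound 4 (0.80 log units; beyond the scatter), so two singly substituted phenyl groups with the substituent at the same ring position need not read alike. The 4-cyanophenyl also separates from the 3-fluorophenyl, the weakest group until now, with a 2.7-fold higher number from compound 2 to compound 4 (0.42 log units; beyond the scatter), and the exchange for the 3,5-dimethoxyphenyl gives an 8.6-fold higher number from compound 3 to compound 4 (0.94 log units; beyond the scatter), which makes compound 4 the weakest of the four, its steps to all the others lying beyond the scatter. Nothing available gives a reason for this rise.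

The compounds shown do not separate the nitrile itself from its place on the ring, and a 3-cyanophenyl on the same amide would speak to that question. Nor do they show whether one methoxy group is enough to hold the number near that of compound 3, as a 4-methoxyphenyl would test, or how a 4-carboxyphenyl or 4-aminophenyl would read in this series.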